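Nitro in place of hydrogen: notes on compound 3

This account rests on a few compounds, and the source may have more. Where it says the series, first, only, none or still open, it means among the compounds named here.

Measured so far:
compound 1 `CCCOc1ccc(-c2nc3cc(C(F)(F)F)ccc3[nH]2)cc1` — 524000 nM
compound 2 `FC(F)(F)c1ccc2[nH]c(-c3ccccc3)nc2c1` — 369000 nM
compound 3 `O=[N+]([O-])c1ccccc1-c1nc2cc(C(F)(F)F)ccc2[nH]1` — not yet measured

In a functional assay on aorta (Rattus norvegicus, strain Wistar) for inhibition, with a stated time of 60 min (on this read-out lower numbers stand for an effect already at smaller amounts and higher numbers for an effect only at larger amounts of compound), compound 1 gives 524000 nM and compound 2 gives 369000 nM. Compound 2 stands alongside compound 1 rather than apart from it: the step of a 1.4-fold lower number from compound 1 to compound 2 (0.15 log units; within the scatter) lies within the scatter, so the two numbers cannot be told apart.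

Compound 3 carries nitro in place of hydrogen on an aromatic carbon. Within the data shown here, the only measured step that touches the same six-membered aromatic ring of carbon only is the removal of propoxy from compound 1 to compound 2, a 1.4-fold lower number from compound 1 to compound 2 (0.15 log units; within the scatter), and it did not move the number beyond the scatter. Among the measured compounds shown here, no step with nitro, and none with a group ortho to a large group, has been measured, so the data give no direction for this change.

Compound 3 is therefore expected to stay near compound 2, with a step of a 1.0-fold higher number from compound 2 to compound 3 (0.00 log units; within the scatter) not beyond the scatter; the estimate for compound 3 in this assay is 370000 nM, with a range from 120000 nM to 1100000 nM, kept wide because the series holds nothing that resembles this change.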

Compound 3, half-maximal effective concentration: 3180 nM
For compound 3 the middle estimate is 120-fold (2.07 log units) above the measured one; measured number below the stated range.
By their numbers in this assay, from the lowest: compound 3; then compounds 2 and 1 (each within the scatter of the next).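

In this assay, among these compounds, the place ortho to a large group on the six-membered aromatic ring of carbon only proves able to shift the read-out: nitro in place of hydrogen gives a 120-fold lower number from compound 2 to compound 3 (2.06 log units; beyond the scatter), whereas the one earlier change on this ring, a 1.4-fold lower number from compound 1 to compound 2 (0.15 log units; within the scatter), stayed within the scatter. The ring therefore does not tolerate every change with the same indifference, and the flat picture given by compound 1 and compound 2 does not extend to compound 3, although this rests on one group at one place and makes no trend. Nothing at hand accounts for the size of this step.

Whether the step belongs to nitro itself or to substitution at this place in general stays open, and the compounds shown do not tell how an amine, a nitrile or a carboxylic acid at the same place would read. Also open, from the compounds shown here alone, is whether nitro elsewhere on the ring would give a comparable step, and whether the step would persist with a group other than trifluoromethyl on the shared core.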